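The compounds below may be only part of what the source reports. "The series", "measured", "known", "first", "only" and "open" are said of these compounds alone.

Measured compounds and values in an assay on Sf21 cells for inhibition of MAP kinase-interacting serine/threonine-protein kinase 1 (Homo sapiens), read by luminescence and ADP-Glo, with stated times of 10 min and 40 min; on this read-out lower numbers stand for stronger inhibition and higher numbers for weaker inhibition:
- compound 1, `O=C(c1ccc(-c2ccc3ncc(-c4cnc5ccccc5c4)n3c2)cc1)N1CCOCC1`: 154 nM
- compound 2, `NC1CCN(C(=O)c2ccc(-c3ccc4ncc(-c5ccc6cnccc6c5)n4n3)cc2)CC1`: 14.5 nM
- compound 3, `O=C(c1ccc(-c2ccc3ncc(-c4cnc5ccccc5c4)n3c2)cc1)N1CCNCC1`: 67.6 nM

Compound 1 stands at the highest number of the three; its nearest neighbour is compound 3, and the furthest is compound 2. Among the compounds with values here, the only single-point step among the measured compounds is that from compound 1 to compound 3, a 2.3-fold lower number from compound 1 to compound 3 (0.36 log units; beyond the scatter), which concerns the amide end of the molecule and not the bicyclic aryl.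

Compound 4, `O=C(c1ccc(-c2ccc3ncc(-c4ccc5ncccc5c4)n3c2)cc1)N1CCOCC1`, is not yet measured. It differs from compound 1 as follows: quinolin-6-yl in place of quinolin-3-yl on an aromatic carbon. Within the data shown here, no measured pair isolates this change. Among the measured compounds shown here, compound 2 carries a different bicyclic group and a different core and amide, so its value shows only that a compound of this general shape can reach a much lower number, not what the aryl swap alone does. The step from compound 1 to compound 3 does not bear on the quinolinyl attachment point. With nothing to anchor a direction, the expectation for compound 4 is a step within the scatter, a 1.0-fold lower number from compound 1 to compound 4 (0.01 log units; within the scatter), with wide uncertainty either way.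

Compound 4 is therefore estimated at 150 nM, in a range from 50 nM to 500 nM.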

Compound 4, half-maximal inhibitory concentration: 371 nM
For compound 4 the middle estimate is 2.5-fold (0.39 log units) below the measured one, within the range that was stated.
By their numbers in this assay, from the lowest: compound 2; then compound 3; then compound 1; then compound 4.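

In this assay, within the data shown here, replacing quinolin-3-yl with quinolin-6-yl gives a 2.4-fold higher number from compound 1 to compound 4 (0.38 log units; beyond the scatter), the first reading at this position of the shared core, since the earlier step from compound 1 to compound 3 changed only the amide end. The two groups match in heavy atoms, ring types, hydrogen-bond donors and acceptors, which shows that the way the bicyclic group is joined to the core can alone shift the number beyond the scatter, and in the direction of weaker inhibition. Nothing available gives a reason for this step.

A single pair does not show whether the step carries over to the piperazin-1-yl amide of compound 3, or whether quinolin-3-yl is preferred over other attachment points of the quinoline. Also open, from the compounds shown here alone, is how this position responds to a plain phenyl group without a fused second ring, or to a quinolin-3-yl group carrying an amine or a carboxylic acid.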